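Propyl in place of isopropyl on the sulfonyl group

This account rests on a few compounds, and the source may have more. Where it says the series, first, only, none or still open, it means among the compounds named here.

Measured compounds:
Compound 1, `CCS(=O)(=O)N[C@@H]1CCCN(C(C)=O)[C@H]1CO[C@H]1CC[C@@H](C(C)C)CC1`: > 30000 nM
Compound 2, `CC(=O)N1CCC[C@H](NS(C)(=O)=O)[C@@H]1CO[C@H]1CC[C@@H](C(C)C)CC1`: 330 nM
Compound 3, `CC(=O)N1CCC[C@H](NS(=O)(=O)C(C)C)[C@@H]1CO[C@H]1CC[C@@H](C(C)C)CC1`: 940 nM

Of the compounds shown here, three sharing one core have been tested in a functional assay on CHO-K1 cells for agonist activity at Orexin receptor type 2 (Homo sapiens), read by FLIPR and calcium flux; on this read-out lower numbers stand for an effect already at smaller amounts and higher numbers for an effect only at larger amounts of compound. Compound 1 gives only a limit of the assay, > 30000 nM, and no number. Compound 2 gives 330 nM, and compound 3 gives 940 nM, the higher of the two numbers; the step of a 2.8-fold higher number from compound 2 to compound 3 (0.45 log units; beyond the scatter) is modest but beyond the scatter. Compound 4, `CCCS(=O)(=O)N[C@H]1CCCN(C(C)=O)[C@H]1CO[C@H]1CC[C@@H](C(C)C)CC1`, is not yet measured. It differs from compound 3 by propyl in place of isopropyl on a sulfonyl sulfur. For the measured compounds named here, the only measured step that bears on this place is a 2.8-fold higher number from compound 2 to compound 3 (0.45 log units; beyond the scatter), where a larger group on the sulfonyl sulfur raised the number. Compound 4 keeps the same size of group but changes its shape, so the step of a 1.1-fold higher number from compound 3 to compound 4 (0.03 log units; within the scatter) is expected to stay within the scatter. Compound 4 is therefore estimated to give about 1000 nM in this assay, likely between 300 nM and 3500 nM.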

Compound 4, half-maximal effective concentration: 2500 nM
Compound 4: middle estimate off by 2.5-fold (0.40 log units), on the low side, within the range that was stated.
By their numbers in this assay, from the lowest: compound 2; then compound 3; then compound 4. At a limit, above all of these: compound 1.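

In this assay, how the carbons on the sulfonyl sulfur are joined matters, not only how many there are: isopropyl and propyl both have 3 heavy atoms, yet the swap gives a 2.7-fold higher number from compound 3 to compound 4 (0.42 log units; beyond the scatter). The unbranched propyl group therefore ends up furthest from methyl among the three compounds with numbers, at a 7.6-fold higher number from compound 2 to compound 4 (0.88 log units; beyond the scatter), so among compounds 2, 3 and 4 the methyl group on the sulfonyl sulfur gives the lowest number. Nothing measured here accounts for the difference between the branched and unbranched groups.

As far as these compounds go, it remains open whether a longer chain such as butyl would raise the number further, or whether a ring such as cyclopropyl would behave more like isopropyl or propyl. An amine on the sulfonyl sulfur is also untested among the compounds shown.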